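Indole piperidines at the serotonin 1D receptor: compound 4

This account rests on a few compounds, and the source may have more. Where it says the series, first, only, none or still open, it means among the compounds named here.

Measured compounds:
compound 1 `COC[C@H](NC1CCN(CCCc2c[nH]c3ccc(Cn4cncn4)cc23)CC1)c1ccc(F)cc1` — 5 nM
compound 2 `CC(C)=CCCN(C)C1CCN(CCCc2c[nH]c3ccc(-n4cnnc4)cc23)CC1` — 2.6 nM
compound 3 `OC[C@H](NC1CCN(CCCc2c[nH]c3ccc(-n4ccnc4)cc23)CC1)c1ccccc1` — 0.7 nM

In an assay on CHO cells for displacement of a labelled ligand from 5-hydroxytryptamine receptor 1D (Homo sapiens) (on this read-out lower numbers stand for stronger inhibition and higher numbers for weaker inhibition), compound 2 gives 2.6 nM. On the three numbers at hand it stands second highest. Its nearest neighbour, compound 1, gives 5 nM; that gap sits within the scatter, so the two cannot be told apart. Compound 3 gives 0.7 nM, a lower number than compound 2 and beyond the scatter.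

Compound 4 `c1ccc2c(c1)CCC2NCC1CCN(CCCc2c[nH]c3ccc(-n4cnnc4)cc23)CC1` is not yet measured. Against compound 2 the change is ((2,3-dihydro-1H-inden-1-yl)amino)methyl in place of methyl(4-methylpent-3-en-1-yl)amino on a saturated ring carbon. Compound 4 thus carries the hydrogen-bond donor that compound 2 lacks; compounds 1 and 3 also carry a donor at the corresponding position, with compound 1 sitting at 5 nM and compound 3 at 0.7 nM, on either side of compound 2 in this assay. Among the measured compounds shown here, no pair of measured compounds differs in one place, so the step has no direct precedent.

The step from compound 2 to compound 4 is expected to be a 1.0-fold lower number from compound 2 to compound 4 (0.02 log units; within the scatter), that is, none beyond the scatter. For compound 4 the estimate in this assay is 2.5 nM, with a range from 0.6 nM to 10 nM.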

Compound 4, half-maximal inhibitory concentration: 1.1 nM
The estimate for compound 4 lay 2.3-fold (0.36 log units) above the measured number; measured number inside the range.
By their numbers in this assay, from the lowest: compounds 3 and 4 (each within the scatter of the next); then compounds 2 and 1 (each within the scatter of the next).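

In this assay, among the compounds shown here, the replacement of methyl(4-methylpent-3-en-1-yl)amino by ((2,3-dihydro-1H-inden-1-yl)amino)methyl on the saturated ring carbon gives a 2.4-fold lower number from compound 2 to compound 4 (0.37 log units; beyond the scatter), the only single-place step so far. This position therefore accepts a group with a five-membered non-aromatic ring, a six-membered aromatic ring and a hydrogen-bond donor with no loss of inhibition, and the open chain with its double bond is not required, though so many features change together that the modest gain cannot be assigned to any one of them. Nothing on hand offers an explanation for the step.

Still open, on these data alone, is whether the donor matters, which the methylated tertiary amine of the same group could test. Also open, as far as these compounds go, is the role of the methyl link, which the 2,3-dihydro-1H-inden-1-ylamino group attached directly to the ring carbon, or a longer ethyl link, could address.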